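Swapping the aryl group on a sulfur-linked benzyl arm

A few compounds are considered here, and "the series" means these few. Any claim that something is new, unique, unknown or untested is made for them only; others in the source may bear on it.

Of the compounds shown here, three sharing one core have been tested in a toxicity assay on GES1 cells (Homo sapiens) for inhibition, read by MTT assay, with a stated time of 72 h; on this read-out lower numbers stand for stronger inhibition and higher numbers for weaker inhibition. Compound 1 `Cc1cc(N2CC[C@@H](C)[C@@H](N(C)c3ncnc4[nH]ccc34)C2)n2ncnc2n1` gives 57900 nM. Compound 2 `Cc1cc(N2CC[C@@H](C)[C@@H](N(C)c3ncnc4[nH]ccc34)C2)n2nc(SCC3CCCCC3)nc2n1` gives 98200 nM. Compound 3 `Cc1cc(N2CC[C@@H](C)[C@@H](N(C)c3ncnc4[nH]ccc34)C2)n2nc(SCc3ccc(C(F)(F)F)cc3)nc2n1` gives 17300 nM, the lowest of the three numbers, with a 3.3-fold lower number from compound 1 to compound 3 (0.52 log units; beyond the scatter) and a 5.7-fold lower number from compound 2 to compound 3 (0.75 log units; beyond the scatter); the step of a 1.7-fold higher number from compound 1 to compound 2 (0.23 log units; within the scatter) stays within the scatter.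

Compound 4 `Cc1cc(N2CC[C@@H](C)[C@@H](N(C)c3ncnc4[nH]ccc34)C2)n2nc(SCc3cc(Cl)ccc3Cl)nc2n1` differs from compound 3 in one place: 2,5-dichlorophenyl in place of 4-(trifluoromethyl)phenyl on a saturated chain carbon bound to a sulfur. For the measured compounds named here, no measured step exchanges one aromatic ring for another. Going by the values given here, the only step touching this position, from a cyclohexyl to an aromatic ring, gave a 5.7-fold lower number from compound 2 to compound 3 (0.75 log units; beyond the scatter), so an aromatic ring at this place appears to matter; compound 4 keeps one. Among the compounds with values here, with no direct precedent, the expected change from compound 3 to compound 4 is a 1.2-fold higher number from compound 3 to compound 4 (0.06 log units; within the scatter), a step not beyond the scatter. In this assay compound 4 is therefore estimated at 20000 nM, with a range from 8000 nM to 50000 nM.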

Compound 4, half-maximal inhibitory concentration: 87500 nM
The estimate for compound 4 lay 4.4-fold (0.64 log units) below the measured number; the whole stated range lies below it.
By their numbers in this assay, from the lowest: compound 3; then compounds 1, 4 and 2 (each within the scatter of the next).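

In this assay an aromatic ring at this position does not by itself give the low number of compound 3: the 2,5-dichlorophenyl ring of compound 4 is still aromatic, yet the swap undoes that gain (a 5.1-fold higher number from compound 3 to compound 4 (0.70 log units; beyond the scatter)). Compound 4 is not separated from the cyclohexyl arm (a 1.1-fold lower number from compound 2 to compound 4 (0.05 log units; within the scatter)) or from the core with no arm at all (a 1.5-fold higher number from compound 1 to compound 4 (0.18 log units; within the scatter)), so among these compounds the low number belongs to the 4-(trifluoromethyl)phenyl ring alone, not to aromatic rings in general. Nothing available here accounts for the gap between the two rings.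

The swap changes the kind of substituent and where it sits in a single step, so the two changes cannot be told apart. Going by these compounds, how a ring with a single chlorine, an amine or a carboxylic acid would read, or a longer chain in place of the benzyl link, remains open.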